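A few compounds are considered here, and "the series" means these few. Any claim that something is new, unique, unknown or untested is made for them only; others in the source may bear on it.

Among the measured compounds shown here, compound 1 `CCc1ccnc(O[C@@H]2CC[C@@H](C)N(C(=O)c3ccccc3-n3nccn3)C2)c1` stands lowest of the three numbers so far in an assay on CHO-K1 cells for displacement of a labelled ligand from Orexin/Hypocretin receptor type 1 (Homo sapiens), read by radioligand binding (a lower number here means a stronger inhibitor, a higher number a weaker inhibitor), where compound 1 gives 57 nM. Compound 2 `COC(=O)c1ccnc(O[C@@H]2CC[C@@H](C)N(C(=O)c3ccccc3-n3nccn3)C2)c1` gives 310 nM, and compound 3 `C[C@@H]1CC[C@@H](Oc2cc(-c3ccccc3)ccn2)CN1C(=O)c1ccccc1-n1nccn1` gives 360 nM. Both steps away from compound 1 replace the ethyl group: a 5.4-fold higher number from compound 1 to compound 2 (0.74 log units; beyond the scatter) and a 6.3-fold higher number from compound 1 to compound 3 (0.80 log units; beyond the scatter). Compound 4 `C[C@@H]1CC[C@@H](Oc2ccccn2)CN1C(=O)c1ccccc1-n1nccn1` instead removes it, with hydrogen in place of ethyl on an aromatic carbon. For the measured compounds named here, no measured step removes this group outright, but since compound 1 alone keeps it and gives the lowest number, a loss of some size seems more likely than a gain. The expected step is a 2.6-fold higher number from compound 1 to compound 4 (0.42 log units; beyond the scatter), and compound 4 is estimated at 150 nM, within 50 nM to 450 nM.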

Compound 4, inhibition constant: 14000 nM
Beside the measured number, compound 4's estimate is 93-fold (1.97 log units) below it; the whole stated range lies below it.
By their numbers in this assay, from the lowest: compound 1; then compounds 2 and 3 (each within the scatter of the next); then compound 4.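

Leaving only hydrogen on this aromatic carbon, opposite the ring nitrogen, matters far more than exchanging one group for another: hydrogen in place of ethyl gives a 250-fold higher number from compound 1 to compound 4 (2.39 log units; beyond the scatter) and hydrogen in place of methoxycarbonyl gives a 45-fold higher number from compound 2 to compound 4 (1.65 log units; beyond the scatter) and hydrogen in place of phenyl gives a 39-fold higher number from compound 3 to compound 4 (1.59 log units; beyond the scatter) in the same direction. So ethyl, methoxycarbonyl and phenyl all give far lower numbers than hydrogen, even though they differ widely in kind. Nothing measured here explains why hydrogen gives so much higher a number.
As far as these compounds go, whether methyl, the smallest carbon group, or a single chlorine atom would already recover most of the loss remains open. So does whether a longer chain such as propyl would go lower than ethyl.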